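The compounds below may be only part of what the source reports. "The series", "measured", "known", "first", "only" and "open" are said of these compounds alone.

Compound 1 `Clc1ccc(-c2noc(-c3cc4cc(Cl)ccc4[nH]3)n2)cc1` gives in a functional assay on Jurkat cells (Homo sapiens) for antiproliferative activity, read by WST assay, with a stated time of 72 h (a higher number here means a weaker inhibitor, a lower number a stronger inhibitor), a limit rather than a number: > 50000 nM.
Compound 2 `Cn1c(-c2nc(-c3ccc(Cl)cc3)no2)cc2cc(Cl)ccc21` gives in this assay likewise only a limit: > 50000 nM.
Compound 3 `COc1ccc(-c2noc(-c3cc4ccccc4[nH]3)n2)cc1` gives in this assay also only a limit: > 50000 nM.

All three measured compounds share an aryl-oxadiazole attached to a fused bicyclic core, and none of them reaches a measurable value in this assay; the limit of > 50000 nM in this assay, at which 3 of the 3 values shown sit, marks where every value sits. Compound 2 differs from compound 1 by methyl in place of hydrogen on an aromatic nitrogen, and the step that the two limits leave unreadable from compound 1 to compound 2 is therefore unreadable: both ends are limits, so neither an improvement nor a loss can be read from this pair.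

Compound 4 `COc1ccc(-c2noc(-c3cc4ccccc4n3C)n2)cc1` has not yet been measured. It differs from compound 3 by methyl in place of hydrogen on an aromatic nitrogen, the same change as that from compound 1 to compound 2, made here on the core of compound 3. The difference between the core of compound 1 and the core of compound 3 is not broken down here.

For the step that the limit leaves unreadable from compound 3 to compound 4 the estimate rests only on the fact that compound 1 gives > 50000 nM and compound 2 gives > 50000 nM, so that the same change left the earlier pair at the limit, and on compound 3 itself giving > 50000 nM. Compound 4 is therefore expected to give about 60000 nM, with a likely range from 20000 nM to 200000 nM, and most probably only a limit again.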

Compound 4, half-maximal inhibitory concentration: > 50000 nM
Compound 4 was reported as a limit; the forecaster's own chance of this, stated with the estimate: 85%; the middle value is on the limit's open side.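

Compound 3 and compound 4 are both reported in this assay only as limits, so no step can be read between them, just as none can be read between compound 1 and compound 2. The compounds shown leave open whether methyl in place of hydrogen on an aromatic nitrogen changes the activity at all, since every result stands at one limit: the limit of > 50000 nM in this assay, at which 4 of the 4 values shown sit.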